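Shortening the Nitrogen Substituent from Neopentyl to Propyl

A few compounds are considered here, and "the series" means these few. Any claim that something is new, unique, unknown or untested is made for them only; others in the source may bear on it.

Compound 3 `CC(C)c1onc(-c2c(Cl)cccc2Cl)c1COc1ccc(-c2nc3ccc(C(=O)O)cc3n2CC(C)(C)C)cc1` is one of three compounds built on a shared core. In an assay on Huh-7 cells for agonist activity at Bile acid receptor (Homo sapiens), read by a luciferase reporter (a lower number here means that less compound is needed, a higher number that more compound is needed for the effect), compound 3 gives 13 nM, the highest of the three numbers, although compound 2 `CC(C)c1onc(-c2c(Cl)cccc2Cl)c1COc1ccc(-c2nc3ccc(C(=O)O)cc3n2CC2CCCCC2)c(F)c1` with 7.8 nM lies within the scatter of it; compound 1 `CC(C)c1onc(-c2c(Cl)cccc2Cl)c1COc1ccc(-c2nc3ccc(C(=O)O)cc3n2Cc2ccc(F)cc2)cc1` gives 3.31 nM, which is beyond the scatter. Going by the values given here, the only measured change at this position is a 3.9-fold higher number from compound 1 to compound 3 (0.59 log units; beyond the scatter), a modest rise. Compound 4 `CCCn1c(-c2ccc(OCc3c(-c4c(Cl)cccc4Cl)noc3C(C)C)cc2)nc2ccc(C(=O)O)cc21` carries ethyl in place of tert-butyl on a saturated chain carbon bound to an aromatic nitrogen. No measured pair compares tert-butyl with ethyl at this carbon, so the direction of this change is not shown by the data. The expected step of a 1.1-fold lower number from compound 3 to compound 4 (0.03 log units; within the scatter) is therefore small, likely within the scatter. For compound 4 the estimate is 12 nM, with a range from 4 nM to 40 nM.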

Compound 4, half-maximal effective concentration: 9.3 nM
Estimate against measurement, compound 4: 1.3-fold (0.11 log units) above; measured number inside the range.
By their numbers in this assay, from the lowest: compound 1; then compounds 2, 4 and 3 (each within the scatter of the next).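

In this assay, the change from neopentyl to propyl gives a 1.4-fold lower number from compound 3 to compound 4 (0.15 log units; within the scatter), so this pair does not separate the tert-butyl and ethyl ends of the chain. Ethyl in place of 4-fluorophenyl gives a 2.8-fold higher number from compound 1 to compound 4 (0.45 log units; beyond the scatter), which puts this second chain, like the neopentyl, on the higher side of compound 1. Nothing measured here gives a reason for these numbers. Still open, on these data alone, is whether a longer chain, or a chain ending in an amine or a hydroxyl group, would stay with compound 3 and compound 4 or come closer to compound 1.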